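The source may hold more compounds than are shown below. What is called first, only, known or untested is meant among the compounds shown, and "the series" means these compounds.

Measured in a functional assay on DU-145 cells (Homo sapiens) for inhibition, read by trypan blue exclusion, with a stated time of 72 h; on this read-out higher numbers stand for weaker inhibition and lower numbers for stronger inhibition:
- compound 1 `CCCn1c(=O)c(S(=O)(=O)c2ccc(F)cc2F)cc2cnc(Nc3ccc4[nH]ccc4c3)nc21`: 1000 nM
- compound 2 `O=c1c(S(=O)(=O)c2ccc(F)cc2F)cc2cnc(Nc3ccc4[nH]ccc4c3)nc2n1C1CCCC1`: 5000 nM
- compound 3 `CCn1c(=O)c(S(=O)(=O)c2ccc(F)cc2F)cc2cnc(Nc3ccc4[nH]ccc4c3)nc21`: 750 nM

Compound 3 shares the low end of these numbers with compound 1, the two lying within the scatter of each other, while compound 2 stands apart: a 6.7-fold lower number from compound 2 to compound 3 (0.82 log units; beyond the scatter). Compound 4 `O=c1c(S(=O)(=O)c2ccc(F)cc2F)cc2cnc(Nc3ccc4[nH]ccc4c3)nc2n1CC1CCCC1` differs from compound 3 as follows: cyclopentyl in place of methyl on a saturated chain carbon bound to an aromatic nitrogen. The ethyl thus becomes cyclopentylmethyl.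

Among the compounds with values here, two measured steps bear on this. Changing the chain length barely registers, with a 1.3-fold lower number from compound 1 to compound 3 (0.12 log units; within the scatter). Bringing in a ring costs more, with a 5.0-fold higher number from compound 1 to compound 2 (0.70 log units; beyond the scatter). Within the data shown here, no measured compound has a ring attached through a chain carbon, so the ring step is only a rough guide. The expected change is a 2.7-fold higher number from compound 3 to compound 4 (0.43 log units; beyond the scatter), a moderate move towards a higher number. For compound 4 the estimate is 2000 nM, with an expected range of 700 nM to 6000 nM.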

Compound 4, half-maximal inhibitory concentration: 10000 nM
Beside the measured number, compound 4's estimate is 5.0-fold (0.70 log units) below it; the whole stated range lies below it.
By their numbers in this assay, from the lowest: compounds 3 and 1 (each within the scatter of the next); then compounds 2 and 4 (each within the scatter of the next).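

Moving the cyclopentyl ring out onto a chain carbon does not bring back the low numbers of the small open chains (a 13-fold higher number from compound 3 to compound 4 (1.12 log units; beyond the scatter)), and the propyl compound gives the same picture (a 10-fold higher number from compound 1 to compound 4 (1.00 log units; beyond the scatter)). The added chain carbon makes no readable difference compared with the directly attached ring (a 2.0-fold higher number from compound 2 to compound 4 (0.30 log units; within the scatter)), so both ring-bearing groups sit high here. No measured evidence explains this. From the compounds shown here alone, whether a longer open chain such as butyl, or a chain ending in an amine, would stay with the low numbers remains open.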